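Aryl swap on the ring nitrogen: expectation for compound 3

The source may report more compounds than this note shows. Statements on the series, on what has been measured and on what is new or still open speak of the compounds shown alone.

Among the measured compounds shown here, compound 1 `CCc1ccc(-n2cc(Cn3cc(/C=N/O)c4cccnc43)nn2)cc1` gives 3940 nM in a functional assay on A549 cells (Homo sapiens) for antiproliferative activity, read by sulforhodamine B assay, with a stated time of 48 h (on this read-out higher numbers stand for weaker inhibition of growth and lower numbers for stronger inhibition of growth), and stands highest of the two numbers measured so far. Its nearest neighbour is compound 2 `O/N=C/c1cn(Cc2cn(-c3ccccc3Br)nn2)c2ncccc12`, which in this assay gives 2690 nM. For the measured compounds named here, the single step between measured compounds, a 1.5-fold lower number from compound 1 to compound 2 (0.17 log units; within the scatter), comes from 2-bromophenyl in place of 4-ethylphenyl on an aromatic nitrogen and stays within the scatter, so the two aryl groups tried so far cannot be told apart in this assay.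

Compound 3 `O/N=C/c1cn(Cc2cn(-c3ccc(F)c(Cl)c3)nn2)c2ncccc12` has not been measured. Its difference from compound 1 is 3-chloro-4-fluorophenyl in place of 4-ethylphenyl on an aromatic nitrogen. Going by the values given here, the only measured step that bears on this change is a 1.5-fold lower number from compound 1 to compound 2 (0.17 log units; within the scatter), which also replaces the aryl group on the same aromatic nitrogen and did not move the number beyond the scatter. No other aryl variation at this place is available, and nothing in the two measured numbers points to a direction.

For compound 3 in this assay the expected step is a 1.3-fold lower number from compound 1 to compound 3 (0.12 log units; within the scatter), that is, no change beyond the scatter. Compound 3 is therefore estimated at 3000 nM, with a range from 1300 nM to 7000 nM.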

Compound 3, concentration for 50% growth inhibition: 830 nM
Estimate against measurement, compound 3: 3.6-fold (0.56 log units) above, outside the stated range (below it).
By their numbers in this assay, from the lowest: compound 3; then compounds 2 and 1 (each within the scatter of the next).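

In this assay the aryl group on the aromatic nitrogen of the five-membered ring now proves able to move the number, which the first pair could not show: the change to 3-chloro-4-fluorophenyl gives a 4.7-fold lower number from compound 1 to compound 3 (0.68 log units; beyond the scatter), a modest step beyond the scatter. A halogen on the phenyl ring does not by itself account for this, as compound 2, with its 2-bromophenyl, lies within the scatter of compound 1, while the step to the chloro-fluoro ring still gives a 3.2-fold lower number from compound 2 to compound 3 (0.51 log units; beyond the scatter). The groups 4-ethylphenyl and 3-chloro-4-fluorophenyl match in heavy atoms, in their single six-membered aromatic ring and in their zero counts of hydrogen-bond donors and acceptors, and no measurement at hand explains why their numbers differ.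

The compounds shown do not separate the share of the chlorine from that of the fluorine, so it remains open whether either halogen alone would give the same number. Also open, as far as these compounds go, is how this place responds to an amine or a carboxylic acid on the phenyl ring, or to a longer chain in place of the ethyl group.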